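From hydroxymethyl to 3-hydroxypropyl: compound 2 to compound 4

The source may hold more compounds than are shown below. What is called first, only, known or untested is meant among the compounds shown, and "the series" means these compounds.

In a toxicity assay on MT2 cells (Homo sapiens) for cytotoxicity, read by XTT assay, with a stated time of 4 days (a lower number here means that less compound is tolerated, a higher number that more compound is tolerated), compound 2 `Cc1ccc(-c2ccc(C(=O)N[C@@H](c3nc(C)c(CO)s3)[C@@H]3CCCCN3)[nH]2)cc1F` gives 28200 nM. Compound 1 `Cc1ccc(-c2ccc(C(=O)N[C@H](c3nc(C)c(CO)s3)[C@@H]3CCCCN3)[nH]2)cc1F` gives 16100 nM. Compound 3 `Cc1nc([C@H](NC(=O)c2ccc(-c3ccc(Cl)c(F)c3)[nH]2)[C@@H]2CCCCN2)sc1CCO` gives 16800 nM. All three values lie within the scatter of one another, so compound 2 has no separate standing among them.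

Compound 4 `Cc1ccc(-c2ccc(C(=O)N[C@@H](c3nc(C)c(CCCO)s3)[C@@H]3CCCCN3)[nH]2)cc1F` lengthens the chain of compound 2, from hydroxymethyl to 3-hydroxypropyl: 2-hydroxyethyl in place of hydroxy on a saturated chain carbon bound to an aromatic carbon. Among the compounds with values here, the one measured step is a 1.8-fold higher number from compound 1 to compound 2 (0.24 log units; within the scatter). It rests on (the fact that compounds 1 and 2 differ only in the configuration as drawn), so it does not test chain length. The closest indirect evidence is compound 3, which carries a 2-hydroxyethyl group and also differs from compound 2 elsewhere. Yet compound 3 gives 16800 nM, which stays within the scatter of compound 2. On that limited basis, no step beyond the scatter is expected in this assay.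

The expected change is a 1.4-fold lower number from compound 2 to compound 4 (0.15 log units; within the scatter).

The estimated value for compound 4 is 20000 nM, with an expected range of 9000 nM to 42000 nM.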

Compound 4, half-maximal cytotoxic concentration: 20600 nM
Estimate against measurement, compound 4: 1.0-fold (0.01 log units) below; the range from low to high includes it.
By their numbers in this assay, from the lowest: compounds 1, 3, 4 and 2 (each within the scatter of the next).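

With the rest of compound 2 held fixed, the chain change from hydroxymethyl to 3-hydroxypropyl gives a 1.4-fold lower number from compound 2 to compound 4 (0.14 log units; within the scatter) in this assay. Within the data shown here, this is the one direct reading of chain length at this position, since the earlier step changed only the configuration as drawn and compound 3 also differs elsewhere. Here, 2-hydroxyethyl in place of hydroxy on a saturated chain carbon bound to an aromatic carbon leaves the number within the scatter, and nothing in the data shown gives a cause for that.

Every compound shown keeps a hydroxy group on this chain, so the reading for a plain propyl chain, an amine or a carboxylic acid in its place remains open. Also open, as far as these compounds go, are a chain longer than 3-hydroxypropyl and the same change in the configuration of compound 1.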